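The source may hold more compounds than are shown below. What is called first, only, known or untested is meant among the compounds shown, and "the series" means these compounds.

Measured compounds:
- compound 1 `COC(=O)c1cccc(C(=O)N2CCC(N(C3CC3)S(=O)(=O)c3cccc(C(F)(F)F)c3)CC2)c1` — "not determined" (no result reported) in an assay on cells for inhibition of Voltage-dependent L-type calcium channel subunit alpha-1C (Homo sapiens), read by FLIPR and calcium flux, tested at 1 uM; on this read-out lower numbers stand for a weaker effect and higher numbers for a stronger effect at the one concentration tested
- compound 2 `NC(=O)c1ccc(C(=O)N2CCC(N(C3CC3)S(=O)(=O)c3cccc(C(F)(F)F)c3)CC2)cc1` — 0%

In this assay, among the compounds with values here, compound 2 gives 0%, and this is the only number: compound 1 carries "not determined" (no result reported), so compound 2 stands alone, with nothing measured to set beside it. Within the data shown here, no pair of measured compounds differs in a single place, so no measured step within this assay is available.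

Compound 3 `O=C(c1ccc(OC(F)(F)F)cc1)N1CCC(N(C2CC2)S(=O)(=O)c2cccc(C(F)(F)F)c2)CC1` differs from compound 2 by trifluoromethoxy in place of carbamoyl on an aromatic carbon; cut one bond further out, the change reads 4-carbamoylphenyl to 4-(trifluoromethoxy)phenyl. The shown data hold no step of this or any related kind, so no direction can be read from them. The expectation is therefore a step from compound 2 to compound 3 of a number 8 percentage points higher from compound 2 to compound 3 (within the scatter) in this assay, that is, none beyond the usual scatter, with a small lean upward carried only by the uncertainty around a value sitting at the floor of the read-out. On that basis compound 3 is estimated at 8% in this assay, with a range from -10% to 30%.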

Compound 3, a percentage reported as inhibition, at one concentration (the size of the read-out at that concentration, not a potency): 73%
Compound 3: the middle estimate sits 65 percentage points below what was measured; the whole stated range lies below it.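

In this assay, trifluoromethoxy in place of carbamoyl on an aromatic carbon, para to a large group, gives a number 73 percentage points higher from compound 2 to compound 3 (beyond the scatter), so this position is not silent: the group held there can move the read-out from the floor to a clear effect. The change alters several counted features at once (heavy atoms, fluorine and hydrogen-bond donors), so this single step cannot show which of them accounts for the difference. No measurement available here bears on why the read-out moves so far.

As far as these compounds go, whether a methoxy group, a chlorine atom, an amine or a carboxylic acid at this place would sit nearer compound 2 or compound 3 remains open, so one step defines no trend. Also open, from the compounds shown here alone, is how compound 3 would behave across a range of concentrations in this assay, since a single-concentration read-out gives the size of the effect and not a potency.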